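A few compounds are considered here, and "the series" means these few. Any claim that something is new, unique, unknown or untested is made for them only; others in the source may bear on it.

Among the measured compounds shown here, compound 3 `Cc1c(CC(C)C)c(=O)on1C(=O)N1CCCCC1` gives 5 nM in an assay (strain Wistar) for inhibition of Hormone-sensitive lipase (Rattus norvegicus), read by spectrophotometry (a higher number here means a weaker inhibitor, a lower number a stronger inhibitor), the lowest of the three numbers so far; compound 2 `CCc1c(C)n(C(=O)N2CCCCC2)oc1=O` gives 18 nM and compound 1 `Cc1c(S(=O)(=O)c2ccc(Cl)cc2)c(=O)on1C(=O)N1CCCCC1` gives 35 nM. For the measured compounds named here, the single step between close relatives, a 3.6-fold lower number from compound 2 to compound 3 (0.56 log units; beyond the scatter), came from isopropyl in place of methyl on a saturated chain carbon bound to an aromatic carbon. Compound 4 `Cc1c(C2CCOCC2)c(=O)on1C(=O)N1CCCCC1` alters compound 3 on an aromatic carbon of the shared core: oxan-4-yl in place of isobutyl on an aromatic carbon. Going by the values given here, no measured step exchanges a chain for a ring with a hydrogen-bond acceptor, so the modest size of the step from compound 2 to compound 3 is the only guide, and a modest shift in either direction is expected, a 2.4-fold higher number from compound 3 to compound 4 (0.38 log units; beyond the scatter). Compound 4 is therefore estimated at 12 nM, with a likely range from 3 nM to 50 nM.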

Compound 4, half-maximal inhibitory concentration: 71 nM
Compound 4: the middle estimate sits 5.9-fold (0.77 log units) below what was measured, and the stated range ends below it.
By their numbers in this assay, from the lowest: compound 3; then compounds 2 and 1 (each within the scatter of the next); then compound 4.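

On this aromatic carbon of the shared core, a chain cannot simply be exchanged for a ring: in this assay, oxan-4-yl in place of isobutyl brings a large loss (a 14-fold higher number from compound 3 to compound 4 (1.15 log units; beyond the scatter)), and oxan-4-yl in place of ethyl brings a smaller one (a 3.9-fold higher number from compound 2 to compound 4 (0.60 log units; beyond the scatter)). Both steps point the same way, so isobutyl and ethyl each give a lower number here than oxan-4-yl. Nothing available explains this rise.

From the compounds shown here alone, whether the ring or its oxygen drives the rise stays open, and cyclohexyl, the same ring without oxygen, would separate the two. How a chain longer than isobutyl would fare here is also unknown.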